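A few compounds are considered here, and "the series" means these few. Any claim that something is new, unique, unknown or untested is made for them only; others in the source may bear on it.

Measured in a functional assay on CHO cells for agonist activity at Alpha-1A adrenergic receptor (Homo sapiens), read by FLIPR and calcium flux; on this read-out lower numbers stand for smaller maximal responses and higher numbers for larger maximal responses:
compound 1 `Cn1nccc1-c1cccc2c1CCC2c1ncc[nH]1` gives 58%
compound 2 `CS(=O)(=O)Nc1c(Cl)ccc2c1CCCC2c1ncc[nH]1` gives 61%
compound 3 `Cc1ccc2c(c1NS(C)(=O)=O)CCC2c1ncc[nH]1` gives 83%

Compound 1 holds the lowest of the three numbers in this assay, though compound 2 lies within the usual scatter of it; only compound 3 stands beyond the scatter above compound 1. Going by the values given here, no step between two measured compounds differing in one place is available, so the gap between compound 1 and compound 3 cannot be assigned to a single change.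

Compound 4 `CCS(=O)(=O)Nc1cccc2c1CCC2c1ncc[nH]1` differs from compound 1 thus: (ethylsulfonyl)amino in place of 1-methyl-1H-pyrazol-5-yl on an aromatic carbon. Among the compounds with values here, with no comparable step among the measured compounds, the direction is uncertain; a modest upward step in this assay is expected, of size a number 10 percentage points higher from compound 1 to compound 4 (within the scatter). Compound 4 is expected to give 68%, in a range from 50% to 88%.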

Compound 4, largest response reached (Emax), in percent of the reference or control that the assay uses: 86%
Compound 4: middle estimate off by 18 percentage points, on the low side, within the range that was stated.
By their numbers in this assay, from the lowest: compounds 1 and 2 (each within the scatter of the next); then compounds 3 and 4 (each within the scatter of the next).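

In this assay, going by these compounds alone, (ethylsulfonyl)amino in place of 1-methyl-1H-pyrazol-5-yl on an aromatic carbon gives a step of a number 28 percentage points higher from compound 1 to compound 4 (beyond the scatter), the only single-place step so far. The maximal response therefore depends on the group at this carbon, and the ring of compound 1 is not needed there for the larger response of compound 4. No evidence on the cause of the step is available.

From the compounds shown here alone, whether the sulfonyl, the amino hydrogen or the ethyl chain carries the step stays open. A propylsulfonylamino group, a plain amine or a carboxylic acid at this carbon would help to separate these parts.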